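Two Chlorines for an Acetamide on the Sulfonyl Arm

A few compounds are considered here, and "the series" means these few. Any claim that something is new, unique, unknown or untested is made for them only; others in the source may bear on it.

Compound 1 `CC(=O)Nc1ccc(S(=O)(=O)NNC(=O)c2cccnc2Nc2ccc(Cl)cc2)cc1` reaches only the limit of a functional assay on HOP-92 cells (Homo sapiens) for antiproliferative activity; on this read-out lower numbers stand for stronger inhibition of growth and higher numbers for weaker inhibition of growth: its result of > 100000 nM is a limit rather than a number, so it stands at the limit of > 100000 nM in this assay, at which 1 of the 2 values shown sits. Compound 2 `O=C(NNS(=O)(=O)c1ccc(F)cc1)c1cccnc1Nc1ccc(Cl)cc1Cl`, a related compound, gives 36300 nM in this assay. Compound 3 `O=C(NNS(=O)(=O)c1ccc(Cl)cc1Cl)c1cccnc1Nc1ccc(Cl)cc1` differs from compound 1 by 2,4-dichlorophenyl in place of 4-acetamidophenyl on a sulfonyl sulfur. Within the data shown here, no measured pair isolates this change, so the size of the step is uncertain. Because compound 2 gives 36300 nM, a move into the measurable range is expected. The expected step of an at least 2.5-fold lower number from compound 1 to compound 3 (0.39 log units; beyond the scatter) points toward stronger growth inhibition, and compound 3 is estimated at 40000 nM, between 12000 nM and 130000 nM.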

Compound 3, concentration for total growth inhibition: 40700 nM
Compound 3: the middle estimate sits 1.0-fold (0.01 log units) below what was measured, within the range that was stated.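

Putting 2,4-dichlorophenyl in place of 4-acetamidophenyl on the sulfonyl sulfur brings the result into the measurable range of this assay (an at least 2.4-fold lower number from compound 1 to compound 3 (0.39 log units; beyond the scatter)). Among these compounds, compound 3 differs from compound 1 in this one place only, so this pair gives the first direct reading of the change. On these data alone, the full size of the step stays unknown because compound 1 sits at a limit: the limit of > 100000 nM in this assay, at which 1 of the 3 values shown sits.

As far as these compounds go, whether both chlorines are needed remains open. So does whether a plain phenyl or a 4-methoxyphenyl on the sulfonyl sulfur would give a similar result.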